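Adding a Third Methoxy to the Benzyl Ring

The compounds below may be only part of what the source reports. "The series", "measured", "known", "first", "only" and "open" are said of these compounds alone.

Measured compounds:
compound 1 `O=C(NCc1cn(Cc2ccc(F)cc2)nn1)c1cn(-c2ccccc2)nc1-c1ccc(Cl)cc1` gives 2800 nM in a functional assay on HeLa cells (Homo sapiens) for antiproliferative activity, read by sulforhodamine B assay, with a stated time of 48 h; a higher number here means a weaker inhibitor of growth, a lower number a stronger inhibitor of growth
compound 2 `O=C(NCc1cn(Cc2ccc(C(F)(F)F)cc2)nn1)c1cn(-c2ccccc2)nc1-c1ccc(Cl)cc1` gives 1900 nM in this assay
compound 3 `COc1cc(Cn2cc(CNC(=O)c3cn(-c4ccccc4)nc3-c3ccc(Cl)cc3)nn2)cc(OC)c1` gives 730 nM in this assay

All three share one core and differ only in the aryl group carried on the benzyl arm of the triazole. Compound 3 stands at the lowest number of the three in this assay; the nearest is compound 2, as shown by a 2.6-fold lower number from compound 2 to compound 3 (0.42 log units; beyond the scatter), and the furthest is compound 1, as shown by a 3.8-fold lower number from compound 1 to compound 3 (0.58 log units; beyond the scatter). The change within the first pair, a 1.5-fold lower number from compound 1 to compound 2 (0.17 log units; within the scatter), stays inside the scatter.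

Compound 4 `COc1cc(Cn2cc(CNC(=O)c3cn(-c4ccccc4)nc3-c3ccc(Cl)cc3)nn2)cc(OC)c1OC` is not yet measured. It differs from compound 3 by methoxy in place of hydrogen on an aromatic carbon.

For the measured compounds named here, none of the measured steps adds a group to the dimethoxyphenyl; the two steps that reach compound 3 both replace one aryl with another, and both are modest. The new change is smaller than either, so the most that can be read from them is that this arm tolerates variation. The expected step of a 1.1-fold lower number from compound 3 to compound 4 (0.05 log units; within the scatter) is therefore no more than modest, with no clear direction. Compound 4 is estimated at 650 nM, within a range from 250 nM to 1700 nM.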

Compound 4, concentration for 50% growth inhibition: 100 nM
For compound 4 the middle estimate is 6.5-fold (0.81 log units) above the measured one; measured number outside the range, below it.
By their numbers in this assay, from the lowest: compound 4; then compound 3; then compounds 2 and 1 (each within the scatter of the next).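

In this assay, for the compounds shown here, the one methoxy that turns 3,5-dimethoxyphenyl into 3,4,5-trimethoxyphenyl gives a 7.3-fold lower number from compound 3 to compound 4 (0.86 log units; beyond the scatter), a bigger step than any of the swaps of one aryl group for another among the earlier compounds. Going by these compounds alone, this aromatic carbon, ortho to two methoxy groups, is therefore a place where a small addition of 2 heavy atoms goes with a clear change in growth inhibition, something the earlier steps on this arm, all modest or smaller, gave no sign of. Against the aryl groups with a single substituent the steps are large, with a 19-fold lower number from compound 2 to compound 4 (1.28 log units; beyond the scatter) and a 28-fold lower number from compound 1 to compound 4 (1.45 log units; beyond the scatter), though nothing shown here explains why this methoxy has such an effect.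

The compounds shown leave open whether methoxy itself is needed at this carbon, or whether a hydroxyl, an ethoxy or an amine in the same place would do as well. They also leave open whether the two flanking methoxy groups are needed, since a phenyl ring carrying only the single methoxy para to the large group is not among them.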